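Removing the piperazinyl arm from compound 3

This account rests on a few compounds, and the source may have more. Where it says the series, first, only, none or still open, it means among the compounds named here.

Measured so far:
compound 1, `COc1ccc(-c2nc3cc(Cl)c(Cl)cc3[nH]2)cc1`: 1000 nM
compound 2, `Nc1ccc(-c2nc3cc(Cl)c(Cl)cc3[nH]2)cc1`: 17000 nM
compound 3, `CN1CCN(CC(=O)Nc2ccc(-c3nc4cc(Cl)c(Cl)cc4[nH]3)cc2)CC1`: 11000 nM

Of the compounds shown here, three sharing one core have been tested in an ADME assay on MT4 cells (Homo sapiens) for cytotoxicity, read by MTT assay, with a stated time of 96 h; on this read-out lower numbers stand for higher toxicity in this test and higher numbers for lower toxicity in this test. Compound 1 gives 1000 nM, compound 2 gives 17000 nM and compound 3 gives 11000 nM. Among the measured compounds shown here, the one single-point step measured so far is a 17-fold higher number from compound 1 to compound 2 (1.23 log units; beyond the scatter). Compound 3 stands second highest of the three numbers; its values and those of compound 2 lie within the scatter of each other, while compound 1 sits well apart from both.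

Compound 4, `CC(=O)Nc1ccc(-c2nc3cc(Cl)c(Cl)cc3[nH]2)cc1`, is not yet measured in this assay. It differs from compound 3 in one place: hydrogen in place of 4-methylpiperazin-1-yl on a saturated chain carbon bound to a carbonyl carbon. For the measured compounds named here, no measured step touches this position; the only step recorded concerns amino in place of methoxy on an aromatic carbon, which is a different part of the molecule. Since compound 2 and compound 3 already agree within the scatter despite their different substituents on that aromatic carbon, compound 4 is expected to land near them. Compound 4 is thus expected to show a 1.1-fold lower number from compound 3 to compound 4 (0.04 log units; within the scatter), a change not beyond the scatter. For compound 4 the estimate is 10000 nM, with a range from 3000 nM to 30000 nM.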

Compound 4, half-maximal cytotoxic concentration: > 100000 nM
Compound 4: a limit, no number; the forecaster's own chance of this, stated with the estimate: 10%; middle value at least 10-fold (1.00 log units) from the limit.
By their numbers in this assay, from the lowest: compound 1; then compounds 3 and 2 (each within the scatter of the next). At a limit, above all of these: compound 4.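

In this assay compound 4 gives > 100000 nM, which is a limit of the assay and not a number. Hydrogen in place of 4-methylpiperazin-1-yl on a saturated chain carbon bound to a carbonyl carbon is a change beyond the scatter, an at least 9.0-fold higher number from compound 3 to compound 4 (0.95 log units; beyond the scatter), so the first measured step at this position shows that the read-out responds to it. The agreement of compound 2 and compound 3 within the scatter does not extend to compound 4, as the other two steps show: an at least 5.8-fold higher number from compound 2 to compound 4 (0.76 log units; beyond the scatter), and an at least 100-fold higher number from compound 1 to compound 4 (2.00 log units; beyond the scatter).

The compounds shown leave open whether a dimethylamino group, a morpholine ring or a carboxylic acid on that chain carbon would stay near compound 3 or reach the limit of compound 4. On these data alone, how far the true value of compound 4 lies past its limit also stays open.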